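Compound 2 to Compound 4: One Bond Shorter

The source may report more compounds than this note shows. Statements on the series, on what has been measured and on what is new or still open speak of the compounds shown alone.

Measured so far in this assay:
- compound 1, `CNC[C@@H]1CCN(c2cc3c(cc2F)c(=O)c(C(=O)O)cn3Cc2ccc(-n3cccn3)cc2)C1`: > 200000 nM
- compound 2, `CNC[C@@H]1CCN(c2c(F)cc3c(=O)c(C(=O)O)cn(Cc4ccc(-c5ccccc5)cc4)c3c2OC)C1`: 155000 nM
- compound 3, `NC[C@@H]1CCN(c2cc3c(cc2F)c(=O)c(C(=O)O)cn3Cc2ccc(-n3cccn3)cc2)C1`: 91600 nM

Of the compounds shown here, three have been tested in an assay on isolated protein for inhibition of DNA topoisomerase 1 (Homo sapiens), with a stated time of 15 min; on this read-out higher numbers stand for weaker inhibition and lower numbers for stronger inhibition. For compound 1 the assay reports only a limit, > 200000 nM, not a number (the limit of > 200000 nM in this assay, at which 1 of the 3 values shown sits). Of the two actual numbers, compound 2 gives the higher one, though compound 3 sits within the usual scatter of it, so the two cannot be told apart.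

Within the data shown here, the one measured step, hydrogen in place of methyl on an amine nitrogen, gave an at least 2.1-fold lower number from compound 1 to compound 3 (0.33 log units; beyond the scatter). That is a different change from the one now followed.

Compound 4, `CN[C@@H]1CCN(c2c(F)cc3c(=O)c(C(=O)O)cn(Cc4ccc(-c5ccccc5)cc4)c3c2OC)C1`, differs from compound 2 by methylamino in place of (methylamino)methyl on a saturated ring carbon. Among the measured compounds shown here, no measured pair shows this shortening of the side chain, so nothing here points to a step in either direction, and the expectation is a step of about a 1.0-fold lower number from compound 2 to compound 4 (0.01 log units; within the scatter), within the scatter. Compound 4 is therefore estimated at 150000 nM, with a range from 40000 nM to 400000 nM.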

Compound 4, half-maximal inhibitory concentration: 57700 nM
Beside the measured number, compound 4's estimate is 2.6-fold (0.41 log units) above it; low and high end bracket the measured number.
By their numbers in this assay, from the lowest: compounds 4, 3 and 2 (each within the scatter of the next, the first and the last beyond it). At a limit, above all of these: compound 1.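

In this assay, replacing (methylamino)methyl with methylamino on the saturated ring carbon gives a 2.7-fold lower number from compound 2 to compound 4 (0.43 log units; beyond the scatter). The earlier step changed only what sits on the amine nitrogen, whereas this one keeps the methyl on that nitrogen and shows that removing the single carbon linking it to the ring also changes the read-out, on the core of compound 2. Nothing among the data given explains why this shorter chain gives the lower number.

On these data alone, whether a plain amino group or a longer chain such as 2-(methylamino)ethyl on the same ring carbon would lower or raise the number remains open. Also open, as far as these compounds go, is whether the same shortening would give a similar step on the core of compound 1.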